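The compounds below may be only part of what the source reports. "The series", "measured", "known", "first", "only" and "open" are said of these compounds alone.

Working notes on the series in a functional assay on CCRF-CEM cells (Homo sapiens) for inhibition; a lower number here means a stronger inhibitor, a higher number a weaker inhibitor. Compound 1 `C#CCN(Cc1ccc2nc(C)nc(O)c2c1)c1ccccc1` gives > 10700 nM, which is a limit. Compound 2 `C#CCN(Cc1ccc2nc(C)nc(O)c2c1)c1cccc(C)c1` gives > 5000 nM, also a limit. Compound 3 `C#CCN(Cc1ccc2nc(C)nc(O)c2c1)c1cccc(C(F)(F)F)c1` gives > 4300 nM, again a limit, so it stands without a number. Compound 4 `C#CCN(Cc1ccc2nc(C)nc(O)c2c1)c1cccc(Br)c1` carries bromo in place of trifluoromethyl on an aromatic carbon. Three measured changes on an aromatic carbon bear on this: a step that the two limits leave unreadable from compound 1 to compound 2, a step that the two limits leave unreadable from compound 1 to compound 3 and a step that the two limits leave unreadable from compound 2 to compound 3. None of them has a readable size, so no step beyond the scatter is expected in this assay. The expected step is a step that the limit leaves unreadable from compound 3 to compound 4. For compound 4 the estimated value is 7000 nM, with an expected range of 2500 nM to 20000 nM.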

Compound 4, half-maximal inhibitory concentration: 5700 nM
Estimate against measurement, compound 4: 1.2-fold (0.09 log units) above; measured number inside the range.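

Bromo on this aromatic carbon, meta to a large group, gives the first value in the series that is not a limit: in this assay compound 4 gives 5700 nM. Bromo in place of hydrogen gives an at least 1.8-fold lower number from compound 1 to compound 4 (0.27 log units; that floor lies within the scatter), so no gain in inhibition beyond the scatter is established. The steps to compound 4 from compound 2 and from compound 3 cannot be read.

Going by these compounds, whether bromo differs at all from methyl or trifluoromethyl here stays open. On these data alone, how an amine or a carboxylic acid on this aromatic carbon would read in this assay also stays open.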